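The source may hold more compounds than are shown below. What is called first, only, known or untested is meant among the compounds shown, and "the series" means these compounds.

Measured so far:
Compound 1 `CC1=C(C(=O)OCC2CCN(C(=O)OC(C)(C)C)CC2)C(c2cccc(Br)c2)C2=C(CC(C)(C)CC2=O)N1` gives 360 nM in an assay on HEK293 cells for inhibition of neurogenic locus notch homolog protein 1 (Homo sapiens), read by a luciferase reporter and resazurin assay, with a stated time of 16 h; on this read-out higher numbers stand for weaker inhibition and lower numbers for stronger inhibition.
Compound 2 `CC1=C(C(=O)OCC2CCN(C(=O)OC(C)(C)C)CC2)C(c2cccc(C(C)C)c2)C2=C(CC(C)(C)CC2=O)N1` gives 3320 nM in this assay.

Among the measured compounds shown here, compound 2 carries the higher of the two numbers; the single step, a 9.2-fold higher number from compound 1 to compound 2 (0.96 log units; beyond the scatter), shows that exchanging the group on the aromatic ring shifts the read-out well beyond the scatter. Compound 3 `CC1=C(C(=O)OCC2CCN(C(=O)OC(C)(C)C)CC2)C(c2ccc3ccccc3n2)C2=C(CC(C)(C)CC2=O)N1` introduces (quinolin-2-yl in place of 3-isopropylphenyl on a saturated ring carbon). For the measured compounds named here, no measured step tests this exchange of the whole ring directly; the step from compound 1 to compound 2 only shows that this position is sensitive. Compound 3 is therefore expected to give 1500 nM, plausibly between 300 nM and 8000 nM. That expectation corresponds to a step of a 2.2-fold lower number from compound 2 to compound 3 (0.35 log units; beyond the scatter), downward, with wide uncertainty.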

Compound 3, half-maximal inhibitory concentration: 330 nM
Estimate against measurement, compound 3: 4.5-fold (0.66 log units) above; low and high end bracket the measured number.
By their numbers in this assay, from the lowest: compounds 3 and 1 (each within the scatter of the next); then compound 2.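

In this assay, quinolin-2-yl in place of 3-isopropylphenyl on this saturated ring carbon gives a 10-fold lower number from compound 2 to compound 3 (1.00 log units; beyond the scatter), so the position also accepts a fused aromatic group with a ring nitrogen. Set against 3-bromophenyl, the same group gives a 1.1-fold lower number from compound 1 to compound 3 (0.04 log units; within the scatter), and the two cannot be told apart on this read-out. Nothing available explains either step. Still open, going by these compounds, is whether a smaller pyridin-2-yl keeps the number, without the fused carbon ring. Also open, on these data alone, is how an amine or a carboxylic acid on the aromatic ring would fare.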